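Isopropylamino to methylamino: solubility working notes

The source may hold more compounds than are shown below. What is called first, only, known or untested is meant among the compounds shown, and "the series" means these compounds.

Measured so far in a physicochemical assay for solubility, read by nephelometry; a higher number here means a more soluble compound, a lower number a less soluble compound:
- compound 1 `CC1(C)C(=O)N(c2ccc(SC(F)(F)F)cc2)C(=O)N1Cc1ccnc(F)c1`: 0.032 ug/mL
- compound 2 `CC1(C)C(=O)N(c2ccc(SC(F)(F)F)cc2)C(=O)N1Cc1ccnc(NCc2ccccc2)c1`: < 0.026 ug/mL (a limit)
- compound 3 `CC(C)Nc1cc(CN2C(=O)N(c3ccc(SC(F)(F)F)cc3)C(=O)C2(C)C)ccn1`: < 0.023 ug/mL (a limit)

Compound 3 has no numerical value, only the limit < 0.023 ug/mL. Compound 2 also has only a limit, so compound 1 alone has a measured number.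

Compound 4 `CNc1cc(CN2C(=O)N(c3ccc(SC(F)(F)F)cc3)C(=O)C2(C)C)ccn1` differs from compound 3 as follows: methyl in place of isopropyl on a nitrogen on an aromatic ring. This places methyl in place of isopropyl on a nitrogen on an aromatic ring.

Among the compounds with values here, two steps bear on this change: an at least 1.3-fold lower number from compound 1 to compound 3 (0.14 log units; that floor lies within the scatter) and an at least 1.2-fold lower number from compound 1 to compound 2 (0.09 log units; that floor lies within the scatter). Within the data shown here, the nearest precedent in kind, a step that the two limits leave unreadable from compound 2 to compound 3, also exchanges one group on that nitrogen for another. No step beyond the scatter is therefore expected in this assay, in either direction.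

The expected step is a number no lower from compound 3 to compound 4 (the limit leaves the size open). A further limit is more likely than not. The estimate for compound 4 is 0.023 ug/mL, with an expected range of 0.01 ug/mL to 0.05 ug/mL.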

Compound 4, solubility: 0.075 ug/mL
For compound 4 the middle estimate is 3.3-fold (0.51 log units) below the measured one; the whole stated range lies below it.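

In this assay, compound 4 is the only one of the amino compounds shown with a measured number rather than a limit: methyl in place of isopropyl gives an at least 3.2-fold higher number from compound 3 to compound 4 (0.51 log units; beyond the scatter), and the comparison with the benzylamino group gives an at least 2.8-fold higher number from compound 2 to compound 4 (0.46 log units; beyond the scatter). Methylamino in place of fluoro gives a 2.3-fold higher number from compound 1 to compound 4 (0.37 log units; beyond the scatter), so among the compounds shown, an amino group at this place does not by itself go with a lower number, and the group on the nitrogen matters. The step from isopropylamino is only a floor because compound 3 stands as a limit: the limit of < 0.023 ug/mL in this assay, at which 1 of the 4 values shown sits.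

The step between benzylamino and isopropylamino cannot be read. Going by these compounds, it remains open where the unsubstituted amino group or ethylamino would fall relative to methylamino, and whether a hydroxyethyl chain on this nitrogen would give a higher number.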